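The source may report more compounds than this note shows. Statements on the series, on what has been measured and on what is new or still open speak of the compounds shown alone.

Three compounds have been measured in a functional assay on the whole organism for activation, with Mus musculus as the target; a lower number here means that less compound is needed, a higher number that more compound is needed for the effect:

Compound 1, `Nc1ncnc2c1nc(O)n2Cc1ccccc1`: 30 mg/kg
Compound 2, `CCCNc1nc(N)c2nc(O)n(Cc3ccccc3)c2n1`: 1 mg/kg
Compound 3, `CCCC[S+]([O-])c1nc(N)c2nc(O)n(Cc3ccccc3)c2n1`: 1 mg/kg

Compound 3 stands level with compound 2 at the digits printed, and together they have the lowest numbers of the three. Compound 1 is the furthest away: a 30-fold lower number from compound 1 to compound 3 (1.48 log units; beyond the scatter).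

Compound 4, `CSc1nc(N)c2nc(O)n(Cc3ccccc3)c2n1`, differs from compound 3 in one place: a group of 2 heavy atoms (1 carbon, 1 sulfur; no ring) in place of a group of 6 heavy atoms (4 carbon, 1 oxygen, 1 sulfur; no ring), on an aromatic carbon.

Two measured steps show what a group at this aromatic carbon does when it replaces hydrogen, and both were large: a 30-fold lower number from compound 1 to compound 2 (1.48 log units; beyond the scatter); a 30-fold lower number from compound 1 to compound 3 (1.48 log units; beyond the scatter). A third step shows what happens when one such group is swapped for another: no change at the digits printed from compound 2 to compound 3 (within the scatter). Compound 4 keeps a group at this carbon, only a smaller one, so the change most resembles the swap, and no step beyond the scatter is expected in this assay, though a slightly higher number cannot be ruled out given the smaller group.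

For compound 4 the estimate in this assay is 2 mg/kg, with a range from 0.7 mg/kg to 8 mg/kg, which is expected to mean a 2.0-fold higher number from compound 3 to compound 4 (0.30 log units; within the scatter).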

Compound 4, minimum effective dose: 0.1 mg/kg
Compound 4: middle estimate off by 20-fold (1.30 log units), on the high side, outside the stated range (below it).
By their numbers in this assay, from the lowest: compound 4; then compounds 2 and 3 (each within the scatter of the next); then compound 1.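

In this assay, the groups at this aromatic carbon turn out not to be interchangeable, even though compound 2 and compound 3 gave the same printed value: methylsulfanyl brings a 10-fold lower number from compound 3 to compound 4 (1.00 log units; beyond the scatter), and likewise a 10-fold lower number from compound 2 to compound 4 (1.00 log units; beyond the scatter). Within the data shown here, measured against hydrogen at this carbon, the effect of adding a group is now much greater than the earlier compounds showed, with a 300-fold lower number from compound 1 to compound 4 (2.48 log units; beyond the scatter). A large group is therefore not needed here, since methylsulfanyl, with 2 heavy atoms, gives the lowest number of the four compounds.

Nothing available explains why this group does better than the others. As far as these compounds go, it also stays open whether the sulfur or the short chain matters more, a question that ethylsulfanyl, methoxy or methylamino at this carbon could help to separate.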